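The source may report more compounds than this note shows. Statements on the series, on what has been measured and on what is new or still open speak of the compounds shown alone.

Within the data shown here, compound 2 `CC1=C(/C=C/C(=O)/C=C/c2ccc(Cl)cc2)C(C)(C)CCC1` in a functional assay on IMR-32 cells (Homo sapiens) for cytotoxicity, read by sulforhodamine B assay, with a stated time of 48 h (a lower number here means a stronger inhibitor, a higher number a weaker inhibitor), gives 52300 nM, the higher of the two numbers measured so far, whereas compound 1 `CC1=C(/C=C/C(=O)/C=C/c2ccccc2)C(C)(C)CCC1` gives 20400 nM. Among the measured compounds shown here, the single measured step, a 2.6-fold higher number from compound 1 to compound 2 (0.41 log units; beyond the scatter), is the swap of hydrogen for chloro. Compound 3 `CC1=C(/C=C/C(=O)/C=C/c2ccc(Br)cc2)C(C)(C)CCC1` differs from compound 2 by bromo in place of chloro on an aromatic carbon. For the measured compounds named here, no measured step swaps one halogen for another, and the only measured step was modest, so the expected change a 1.1-fold higher number from compound 2 to compound 3 (0.02 log units; within the scatter) is none beyond the scatter. Compound 3 is therefore estimated at 55000 nM, with a range from 25000 nM to 120000 nM.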

Compound 3, half-maximal inhibitory concentration: 10400 nM
The estimate for compound 3 lay 5.3-fold (0.72 log units) above the measured number; the whole stated range lies above it.
By their numbers in this assay, from the lowest: compounds 3 and 1 (each within the scatter of the next); then compound 2.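

Swapping one halogen for another at this spot on the aromatic ring is not a neutral change (a 5.0-fold lower number from compound 2 to compound 3 (0.70 log units; beyond the scatter)), even though chloro and bromo each count as one heavy atom. The two halogens do not behave alike here: set against the unsubstituted compound 1, chloro moves the number up (a 2.6-fold higher number from compound 1 to compound 2 (0.41 log units; beyond the scatter)), while bromo stays within the scatter (a 2.0-fold lower number from compound 1 to compound 3 (0.29 log units; within the scatter)). Nothing measured accounts for this difference between the two halogens.

Going by these compounds, whether fluoro or iodo would fall with chloro or with bromo stays open, as does the outcome with a methoxy group or an amine at this position.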